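From Allyloxy to Benzyloxy in a Small Series

The compounds below may be only part of what the source reports. "The series", "measured", "known", "first", "only" and "open" are said of these compounds alone.

Of the compounds shown here, two have been measured so far in a functional assay on a cell-free system (plasma, Oryctolagus cuniculus) for inhibition, with stated times of 5 min, 1 min and 6 min; on this read-out lower numbers stand for stronger inhibition and higher numbers for weaker inhibition. Compound 1, `CCOC(=O)c1c(C)nc(-c2cccc(C#N)c2)n1OCc1ccccc1`, gives 5930 nM, and compound 2, `C=CCOn1c(-c2cccc(C#N)c2)nc(C)c1C(=O)O`, gives 6350 nM. These values lie within the scatter of each other, so compound 2 stands level with compound 1. Their structures differ in more than one place, so the pair does not isolate the effect of any single change.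

Compound 3, `Cc1nc(-c2cccc(C#N)c2)n(OCc2ccccc2)c1C(=O)O`, differs from compound 2 in one place: phenyl in place of vinyl on a saturated chain carbon bound to an oxygen on an aromatic ring. This change turns allyloxy into benzyloxy. Compound 1 also carries benzyloxy and gives 5930 nM, so a large jump is not expected from this change alone. For the measured compounds named here, with only two measured compounds, this expectation remains loose. The estimated step is a 1.8-fold lower number from compound 2 to compound 3 (0.26 log units; within the scatter) in this assay, a modest move toward stronger inhibition that may stay within the scatter. For compound 3, the expected value is 3500 nM, with an estimated range from 800 nM to 15000 nM.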

Compound 3, half-maximal inhibitory concentration: 6240 nM
Beside the measured number, compound 3's estimate is 1.8-fold (0.25 log units) below it; low and high end bracket the measured number.
By their numbers in this assay, from the lowest: compounds 1, 3 and 2 (each within the scatter of the next).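

In this assay, for the compounds shown here, putting phenyl in place of vinyl on a saturated chain carbon bound to an oxygen on an aromatic ring gives a 1.0-fold lower number from compound 2 to compound 3 (0.01 log units; within the scatter) and this is the first clean reading at this position: a much larger group, with a six-membered aromatic ring, leaves the number within the scatter when allyloxy becomes benzyloxy. The second single change, from the ethyl ester to the carboxylic acid, with hydrogen in place of ethyl on an oxygen next to a carbonyl group, gives a 1.1-fold higher number from compound 1 to compound 3 (0.02 log units; within the scatter) and so also stays within the scatter, which means that the two changes separating compound 1 and compound 2 can now be read one at a time. Nothing available explains why the values stay level through these two changes.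

The compounds shown leave open whether a different group on this oxygen, such as a small methyl or a longer chain like hexyl, would move the number beyond the scatter. They also leave open whether an amide or a primary alcohol in place of the carboxylic acid would do so.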